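A few compounds are considered here, and "the series" means these few. Any claim that something is new, unique, unknown or untested is made for them only; others in the source may bear on it.

Working notes on the series. For the measured compounds named here, in a functional assay on U-87MG ATCC cells (Homo sapiens) for cytotoxicity, read by resazurin assay, with a stated time of 48 h (on this read-out lower numbers stand for stronger inhibition and higher numbers for weaker inhibition), compound 1 (`Cc1ccc(/C=C2\CS(=O)(=O)C/C(=C\c3ccc(C)cc3)C2=O)cc1`) gives 4740 nM, the highest of the three numbers so far. Compound 2 (`O=C1/C(=C/c2ccc(F)cc2)CS(=O)(=O)C/C1=C\c1ccc(F)cc1`) gives 2210 nM and compound 3 (`N#Cc1ccc(/C=C2\CS(=O)(=O)C/C(=C\c3ccc(C#N)cc3)C2=O)cc1`) gives 1350 nM. Both lie below compound 1 by more than the usual scatter, while the two of them sit within the scatter of each other. Compound 1 carries methyl on both aromatic rings, compound 2 carries fluoro on both, and compound 3 carries nitrile on both.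

Compound 4 (`Cc1ccc(/C=C2\CS(=O)(=O)C/C(=C\c3ccc([N+](=O)[O-])cc3)C2=O)cc1`) is still unmeasured. It departs from compound 1 on one side only: nitro in place of methyl on an aromatic carbon. In words, this is nitro in place of methyl on an aromatic carbon, 4-methylphenyl to 4-nitrophenyl, with the other 4-methylphenyl group kept. Going by the values given here, no measured compound carries nitro, and none carries two different groups on its aromatic rings, so the data offer no direct precedent.

The nearest guide is that compound 2 at 2210 nM and compound 3 at 1350 nM both replace methyl on both rings and read lower than compound 1. Among the compounds with values here, with only one ring changed, a modest move toward a lower number is expected, and the expected step is a 2.0-fold lower number from compound 1 to compound 4 (0.30 log units; within the scatter). For compound 4 the estimated value is 2400 nM, with an expected range of 1100 nM to 5000 nM.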

Compound 4, half-maximal inhibitory concentration: 1390 nM
Compound 4: middle estimate off by 1.7-fold (0.24 log units), on the high side, within the range that was stated.
By their numbers in this assay, from the lowest: compounds 3, 4 and 2 (each within the scatter of the next); then compound 1.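

In this assay a change on one aromatic ring alone is enough to move the number: nitro in place of methyl, with the other 4-methylphenyl group kept, gives a 3.4-fold lower number from compound 1 to compound 4 (0.53 log units; beyond the scatter) and this step lies beyond the scatter. For the compounds shown here, it is the first step with a single point of change, whereas compounds 2 and 3 each differ from compound 1 on both rings and could not show what one ring contributes. No measurement of any property of these compounds bears on this result, so the step stands as an observation without an assigned cause.

Still open, as far as these compounds go, is whether fluoro or nitrile on one ring alone, with the other 4-methylphenyl group kept, would also give a step beyond the scatter, and whether nitro on both rings would extend the step seen with nitro on one. Going by these compounds alone, also open is how an amine, a carboxylic acid or a methoxy group would read at this same aromatic carbon, since the series so far holds only methyl, fluoro, nitrile and nitro.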